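Swapping chloro for methoxy on a weak antiproliferative compound

The source may report more compounds than this note shows. Statements on the series, on what has been measured and on what is new or still open speak of the compounds shown alone.

Measured in a functional assay on A2780 cells (Homo sapiens) for antiproliferative activity, read by MTT assay, with a stated time of 72 h; a lower number here means a stronger inhibitor, a higher number a weaker inhibitor:
- Compound 1 `COc1ccc(C2CC(c3ccccc3)=NN2C(=O)c2cc3ccccc3o2)cc1`: 4.57 ug/mL
- Compound 2 `O=C(c1cc2ccccc2o1)N1N=C(c2ccc(F)cc2)CC1c1ccc(Cl)cc1`: > 50 ug/mL (a limit of the assay, not a number)

Compound 2 has no exact value on the scale of this assay. Compound 2 stands at a limit: the limit of > 50 ug/mL in this assay, at which 1 of the 2 values shown sits.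

Compound 3 `COc1ccc(C2CC(c3ccc(F)cc3)=NN2C(=O)c2cc3ccccc3o2)cc1` is still to be measured. It departs from compound 2 at one place, with methoxy in place of chloro on an aromatic carbon, para to a large group (methoxy in place of chloro on an aromatic carbon). The same difference reads as 4-chlorophenyl to 4-methoxyphenyl.

Within the data shown here, no measured pair shows this change alone, so its size in this assay can only be judged indirectly. A large step towards stronger inhibition is expected, well beyond the usual scatter. The expectation rests on compound 1, which gives 4.57 ug/mL and bears the 4-methoxyphenyl group that compound 3 gains. The estimate amounts to an at least 6.2-fold lower number from compound 2 to compound 3 (0.79 log units; beyond the scatter). For compound 3 the estimated value is 8 ug/mL, with an expected range from 2 ug/mL to 35 ug/mL.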

Compound 3, half-maximal inhibitory concentration: 23 ug/mL
Compound 3: the middle estimate sits 2.9-fold (0.46 log units) below what was measured; the measured number falls inside the stated range.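

In this assay, the change from 4-chlorophenyl to 4-methoxyphenyl can now be read directly, with the fluoro group held in place, and it gives an at least 2.1-fold lower number from compound 2 to compound 3 (0.33 log units; beyond the scatter). That step is a lower bound on the true size of the change, because compound 2 has no exact value and its reading is a limit: the limit of > 50 ug/mL in this assay, at which 1 of the 3 values shown sits. The second step shows that the 4-methoxyphenyl group does not by itself set the level of activity, since fluoro in place of hydrogen on an aromatic carbon goes with a 5.0-fold higher number from compound 1 to compound 3 (0.70 log units; beyond the scatter), so the result at this position has to be read together with what the other aromatic ring carries.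

The compounds shown leave open whether a hydroxy group, a dimethylamino group or a longer ethoxy chain at the same place would keep, extend or lose the gain seen with methoxy. They also leave open the full size of the step from chloro to methoxy, and whether that step would be the same in a compound that lacks the fluoro group.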